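Methylating the oxime oxygen of compound 1

The source may hold more compounds than are shown below. What is called first, only, known or untested is meant among the compounds shown, and "the series" means these compounds.

Among the measured compounds shown here, compound 1 `O/N=C(/CCN1CCN(c2ccccn2)CC1)c1ccccc1Cl` is one of two compounds measured in a functional assay on HEK293 cells with D(4) dopamine receptor (Homo sapiens) as the target, read by FLIPR; a higher number here means a larger maximal response, a lower number a smaller maximal response. In this assay, for the measured compounds named here, compound 1 gives 64%, and the only other measured compound, compound 2 `Cc1ccccc1/C(CCN1CCN(c2ccccn2)CC1)=N\O`, gives 72% in this assay, so the two numbers lie within the usual scatter of each other. Going by the values given here, the one recorded step, a number 8 percentage points higher from compound 1 to compound 2 (within the scatter), concerns methyl in place of chloro on an aromatic carbon. Compound 3 `CO/N=C(/CCN1CCN(c2ccccn2)CC1)c1ccccc1Cl` differs from compound 1 at a different place: methyl in place of hydrogen on an oxygen. Among the compounds with values here, no measured step touches this oxygen, and the single recorded step at the aromatic carbon was within the scatter. There is thus no basis for expecting a change beyond the scatter in this assay, and compound 3 is expected to give 62%, with a range from 42% to 82%. The expected step of a number 2 percentage points lower from compound 1 to compound 3 (within the scatter) is estimated to stay within the scatter.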

Compound 3, largest response reached (reported as efficacy), in percent of the reference or control that the assay uses: 73%
Estimate against measurement, compound 3: 11 percentage points below; the range from low to high includes it.
By their numbers in this assay, from the lowest: compounds 1, 2 and 3 (each within the scatter of the next).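

In this assay, replacing hydrogen with methyl on the oxygen gives a number 9 percentage points higher from compound 1 to compound 3 (within the scatter), so this hydroxy to methoxy change leaves the maximal response within the scatter. Among the compounds shown here, this is the first reading at this oxygen, as the earlier step concerned only an aromatic carbon; the changes at these two places, each made from compound 1, both stay within the scatter. No available evidence bears on this result.

The compounds shown leave open whether a larger group on this oxygen, such as an ethyl or a benzyl, would also stay within the scatter of compound 1. They also leave open how methoxy on this oxygen would read when paired with methyl in place of chloro on the aromatic carbon.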